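The source may hold more compounds than are shown below. What is called first, only, known or untested is meant among the compounds shown, and "the series" means these compounds.

In a physicochemical assay for solubility, in phosphate buffer, at pH 7.4 (a lower number here means a less soluble compound, a higher number a more soluble compound), the measured compounds are these
Compound 1 `CC(=O)N[C@@H]1CCC[C@H](C(=O)Nc2cc(-c3cnn4c3CCCC4)ccn2)C1` – 730000 nM
Compound 2 `CC(=O)N[C@@H]1CCC[C@H](C(=O)Nc2cc(-c3cnn4c3CCCC4)c(F)cn2)C1` – > 1000000 nM (a limit of the assay, not a number)
Compound 3 `CC(=O)N[C@@H]1CCC[C@H](C(=O)Nc2cc(-c3cnn4ccccc34)c(Cl)cn2)C1` – 45000 nM

Compound 3 with 45000 nM holds the lower of the two exact numbers, and compound 1 with 730000 nM stands above it by more than the scatter. Compound 4 `CC(=O)N[C@@H]1CCC[C@H](C(=O)Nc2cc(-c3nnn4ccccc34)c(Cl)cn2)C1` differs from compound 3 in a single group on an aromatic carbon, ortho to a chloro group, and that difference is a group of 9 heavy atoms (6 carbon, 3 nitrogen; one five-membered aromatic ring with 3 hetero atoms, one six-membered aromatic ring with 1 hetero atom) in place of a group of 9 heavy atoms (7 carbon, 2 nitrogen; one five-membered aromatic ring with 2 hetero atoms, one six-membered aromatic ring with 1 hetero atom), on an aromatic carbon in full.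

For the measured compounds named here, the one measured step, an at least 1.3-fold higher number from compound 1 to compound 2 (0.13 log units; that floor lies within the scatter) for fluoro in place of hydrogen, is a different change and gives no size for this one. The anchor is therefore compound 3 with 45000 nM as its measured value. Going by the values given here, a modest rise in this assay is expected, but no measured step fixes its size, so the range stays wide. The expected change in this estimate is a 2.2-fold higher number from compound 3 to compound 4 (0.35 log units; beyond the scatter) as a central figure. For compound 4 the estimated value is 100000 nM with an expected range from 30000 nM to 350000 nM in repeated measurements.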

Compound 4, solubility: 530000 nM
Estimate against measurement, compound 4: 5.3-fold (0.72 log units) below, and the stated range ends below it.
By their numbers in this assay, from the lowest: compound 3; then compounds 4 and 1 (each within the scatter of the next). At a limit, above all of these: compound 2.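

In this assay, the exchange on an aromatic carbon, ortho to a chloro group, gives a 12-fold higher number from compound 3 to compound 4 (1.07 log units; beyond the scatter), a large step and the first beyond the scatter among the single changes shown. The group that leaves and the group that enters both have 9 heavy atoms and the same ring sizes, and they differ in the 7 carbon, 2 nitrogen against 6 carbon, 3 nitrogen count, so at this place a change of that kind, with no change in heavy-atom count, moves the number far more than any size the earlier step could fix. Nothing measured here accounts for the size of this step.

On these data alone, whether the step would keep its size with fluoro or hydrogen in place of the chloro group remains open. So does the effect of an amine or a carboxylic acid added to the entering group.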